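Chloro for ethoxy on the shared core: cytotoxicity expectation

A few compounds are considered here, and "the series" means these few. Any claim that something is new, unique, unknown or untested is made for them only; others in the source may bear on it.

Measured so far:
compound 1 `CCOc1ccc2oc(/C=C/[S+](C)[O-])cc(=O)c2c1`: 1500 nM
compound 2 `C[S+]([O-])/C=C/c1cc(=O)c2ccccc2o1`: 1900 nM
compound 3 `CCC(=O)Oc1ccc2oc(/C=C/[S+](C)[O-])cc(=O)c2c1`: 2400 nM

In a functional assay on A549 cells (Homo sapiens) for cytotoxicity, with a stated time of 48 h (a higher number here means a weaker inhibitor, a lower number a stronger inhibitor), compound 1 stands lowest of the three numbers, yet its gaps to the others lie within the scatter: a 1.3-fold higher number from compound 1 to compound 2 (0.10 log units; within the scatter) and a 1.6-fold higher number from compound 1 to compound 3 (0.20 log units; within the scatter). Compound 4 `C[S+]([O-])/C=C/c1cc(=O)c2cc(Cl)ccc2o1` differs from compound 1 in one place: chloro in place of ethoxy on an aromatic carbon. Among the measured compounds shown here, no measured step introduces chloro. For the measured compounds named here, the steps that bear on this position are those that remove or exchange the group on the same aromatic carbon, a 1.3-fold higher number from compound 1 to compound 2 (0.10 log units; within the scatter), a 1.6-fold higher number from compound 1 to compound 3 (0.20 log units; within the scatter) and a 1.3-fold higher number from compound 2 to compound 3 (0.10 log units; within the scatter), all within the scatter. The step of a 1.2-fold higher number from compound 1 to compound 4 (0.08 log units; within the scatter) is therefore expected to stay within the scatter, with no clear direction. Compound 4 is estimated at 1800 nM, range 800 nM to 4000 nM.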

Compound 4, half-maximal inhibitory concentration: 1700 nM
Compound 4: the middle estimate sits 1.1-fold (0.02 log units) above what was measured, within the range that was stated.
By their numbers in this assay, from the lowest: compounds 1, 4, 2 and 3 (each within the scatter of the next).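

Chloro on this aromatic carbon adds a fourth substituent state to ethoxy, hydrogen and propanoyloxy in this assay, and all of its steps stay within the scatter (a 1.1-fold higher number from compound 1 to compound 4 (0.05 log units; within the scatter); a 1.1-fold lower number from compound 2 to compound 4 (0.05 log units; within the scatter); a 1.4-fold lower number from compound 3 to compound 4 (0.15 log units; within the scatter)). Exchanging ethoxy for chloro therefore gives no readable change at this position, and the four compounds cannot be ranked. No measurement shown accounts for this flat result.

On these data alone, whether an amine, a carboxylic acid or a longer alkoxy chain on this carbon would move the number beyond the scatter remains open. Chloro on the other carbons of this ring also remains open.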